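Plasma stability across a biaryl ether amide series

The source may report more compounds than this note shows. Statements on the series, on what has been measured and on what is new or still open speak of the compounds shown alone.

Measured compounds:
compound 1 `O=C1c2ccc(OCc3cccc(-c4ccc(C(F)(F)F)cc4F)c3)cc2CN1C1CCCC1`: "not determined" (no result reported) in an ADME assay on a cell-free system (plasma, Rattus norvegicus) for metabolic stability, read by LC-MS, with a stated time of 1 h, at 37 degrees C, tested at 100 uM; a higher number here means that more of the compound is left, a lower number that less of the compound is left
compound 2 `Cn1sc2cc(OCc3cccc(-c4ccc(Cl)c(C(=O)O)c4)c3)ccc2c1=O`: 100%
compound 3 `O=C(O)c1cc(-c2cccc(COc3ccc4c(=O)n(C5CCCC5)sc4c3)c2)ccc1F`: 100%

Compound 1 stands as "not determined" (no result reported) in this assay, so it gives no anchor of its own. The two compounds that do carry a number, compound 2 and compound 3, each show the full amount remaining after the stated time, and these two values lie within the scatter of each other, so nothing separates them.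

Compound 4 `O=C(O)c1ccc(Cl)c(-c2cccc(COc3ccc4c(c3)CN(C3CCCC3)C4=O)c2)c1` is the compound awaiting measurement. It arises from compound 1 by the change (5-carboxy-2-chlorophenyl in place of 2-fluoro-4-(trifluoromethyl)phenyl on an aromatic carbon). Within the data shown here, no measured step between any pair of compounds is available, and compound 1 itself has no value, so no direction or size of step in this assay can be stated from compound 1. What can be said rests on compound 2 and compound 3: both carry a carboxy group on a chlorinated or fluorinated phenyl ring and both remain fully intact, so for compound 4, which likewise carries a 5-carboxy-2-chlorophenyl group, a similarly high remaining fraction is expected. The core of compound 4 differs from that of compound 2 and compound 3, and this part of the comparison carries no data, so the range is kept wide on the lower side. Compound 4 is estimated at 95%, with a range from 78% to 100%.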

Compound 4, percent of the compound remaining: 100%
Compound 4: the middle estimate sits 5 percentage points below what was measured, within the range that was stated.
By their numbers in this assay, from the lowest: compounds 2, 3 and 4 (each within the scatter of the next).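

Among these compounds, compound 4 gives 100% in this assay, while compound 1 stands as "not determined" (no result reported), and no step between the two can be read. No data shown bear on this result. The compounds shown leave open whether any change of group alters the percent remaining in this assay.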